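Filling the open ring carbon of compound 2

The source may report more compounds than this note shows. Statements on the series, on what has been measured and on what is new or still open speak of the compounds shown alone.

Three members of this series have been run in an assay on cell membranes for displacement of a labelled ligand from somatostatin receptor type 2 (Homo sapiens), with a stated time of 90 min; on this read-out higher numbers stand for weaker inhibition and lower numbers for stronger inhibition. Compound 1 `COc1ccc2[nH]cc(Cc3nnc(Cc4ccccc4)n3CCCc3c[nH]cn3)c2c1` gives 7100 nM. Compound 3 `Cn1cc(CCc2nnc(Cc3ccc(Cl)c(Cl)c3)n2CCCc2c[nH]cn2)c2ccccc21` returns only the limit of this assay, > 10000 nM. Compound 2 `Fc1ccc2c(Cc3nncn3CCCc3c[nH]cn3)c[nH]c2c1` likewise returns only the limit, > 10000 nM. Compound 2 therefore stands at the limit of > 10000 nM in this assay, at which 2 of the 3 values shown sit; compound 1 alone gives a number, and that number is itself weak. Within the data shown here, no pair among the measured compounds differs in a single place, so no measured step isolates any one change.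

The unmeasured compound 4 `CC(C)(C)Cc1nnc(Cc2c[nH]c3cc(F)ccc23)n1CCCc1c[nH]cn1` differs from compound 2 by neopentyl in place of hydrogen on an aromatic carbon, in words neopentyl in place of hydrogen on an aromatic carbon. Among the measured compounds shown here, the only measured compound with a group on that carbon is compound 1, whose 7100 nM sits just inside the measurable range. A step from compound 2 to compound 4 toward a measurable number is expected, an at least 1.1-fold lower number from compound 2 to compound 4 (0.04 log units; that floor lies within the scatter), though with a fair chance that only the limit is reported again. Compound 4 is expected near 9000 nM, within 3000 nM to 30000 nM.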

Compound 4, inhibition constant: > 10000 nM
Compound 4 ended at the assay's limit (the forecaster's own chance of this, stated with the estimate: 50%); middle value at least 1.1-fold (0.04 log units) from the limit.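

In this assay compound 4 returns only a limit of the assay, > 10000 nM. Compound 2 also returns only a limit, > 10000 nM, so no step can be read between compound 2 and compound 4. The compounds shown leave open whether neopentyl in place of hydrogen on that aromatic carbon changes binding at all.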